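The source may hold more compounds than are shown below. What is called first, only, known or untested is meant among the compounds shown, and "the series" means these compounds.

Compound 1, `CCOC(=O)c1cc(-c2cccc(OCc3ccccc3)c2)on1`, is the starting point. In an ADME assay on Vero cells (Chlorocebus sabaeus) for cytotoxicity, with a stated time of 72 h (on this read-out higher numbers stand for weaker inhibition and lower numbers for stronger inhibition), compound 1 gives > 128000 nM, a limit of the assay rather than a number. Two close relatives have been measured in the same way. Compound 2, `CCOC(=O)c1cc(-c2cccc(OCc3cccc(OC)c3)c2)on1`, gives > 128000 nM in this assay, again a limit. Compound 3, `CCOC(=O)c1cc(-c2cccc(OCc3ccc(F)c(F)c3)c2)on1`, gives > 128000 nM in this assay, also a limit. The steps among them are a step that the two limits leave unreadable from compound 1 to compound 2, a step that the two limits leave unreadable from compound 1 to compound 3 and a step that the two limits leave unreadable from compound 2 to compound 3, so none of them tells how far apart the three compounds really lie; what is known is only that all three share (the limit of > 128000 nM in this assay, at which 3 of the 3 values shown sit).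

The compound that remains to be measured is compound 4, `CCOC(=O)c1cc(-c2cccc(OCc3ccc(F)cc3F)c2)on1`. Its change from compound 1 is 2,4-difluorophenyl in place of phenyl on a saturated chain carbon bound to an oxygen on an aromatic ring. The steps to compound 2 and compound 3 bear on it most closely, both being changes at the same saturated chain carbon or on the aromatic ring carried by it, and both returned only the limit. On that ground the step is expected to be a number no higher from compound 1 to compound 4 (the limit leaves the size open), with no movement beyond the scatter. Compound 4 is therefore estimated to give 128000 nM in this assay, within the range from 64000 nM to 256000 nM, most probably again reported only as a limit.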

Compound 4, half-maximal inhibitory concentration: > 128000 nM
Compound 4: no number, only a limit; the forecaster's own chance of this, stated with the estimate: 90%; the middle value sits exactly at the limit.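

No step between compound 4 and compound 1, compound 2 or compound 3 can be read in this assay, and all four compounds share one limit of the assay: the limit of > 128000 nM in this assay, at which 4 of the 4 values shown sit.

The compounds shown leave open what number any of the four would give in this assay, and so whether the changes among them shift the read-out at all.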